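A few compounds are considered here, and "the series" means these few. Any claim that something is new, unique, unknown or untested is made for them only; others in the source may bear on it.

Measured compounds:
Compound 1 `CNC(=O)c1cc(Oc2ccc(NC(=O)c3nn(-c4ccccc4C(F)(F)F)c(=O)cc3C)cc2F)ccn1`: in a functional assay on A549 cells (Homo sapiens) for cytotoxicity, read by MTT assay, with a stated time of 72 h (on this read-out higher numbers stand for weaker inhibition and lower numbers for stronger inhibition), compound 1 gives > 40000 nM, which is a limit of the assay and not a number.
Compound 2 `CNC(=O)c1cc(Oc2ccc(NC(=O)c3nn(-c4ccccc4OC(F)(F)F)c(=O)cc3C)cc2F)ccn1`: in this assay compound 2 gives > 40000 nM, again a limit of the assay rather than a number.

Compound 2 therefore stands at the limit of what the assay can report, with no number to place it at. The change from compound 1 to compound 2 is trifluoromethoxy in place of trifluoromethyl on an aromatic carbon, and a step that the two limits leave unreadable from compound 1 to compound 2, since both values are limits; this is summed up in the limit of > 40000 nM in this assay, at which 2 of the 2 values shown sit.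

Compound 3 `CNC(=O)c1cc(Oc2ccc(NC(=O)c3nn(-c4cccc(F)c4)c(=O)cc3C)cc2F)ccn1` differs from compound 2 by 3-fluorophenyl in place of 2-(trifluoromethoxy)phenyl on an aromatic nitrogen. For the measured compounds named here, no measured step on this shared core bears directly on that change, and the only step known is unreadable. Compound 3 is expected to stay near the limit as well, with the expected step that the limit leaves unreadable from compound 2 to compound 3. The estimate for compound 3 is 60000 nM, within 15000 nM to 250000 nM.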

Compound 3, half-maximal inhibitory concentration: 9540 nM
For compound 3 the middle estimate is 6.3-fold (0.80 log units) above the measured one; measured number outside the range, below it.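

In this assay, the group on the aromatic nitrogen now makes a readable difference: 3-fluorophenyl in place of 2-(trifluoromethoxy)phenyl gives an at least 4.1-fold lower number from compound 2 to compound 3 (0.62 log units; beyond the scatter), and 3-fluorophenyl in place of 2-(trifluoromethyl)phenyl gives an at least 4.1-fold lower number from compound 1 to compound 3 (0.62 log units; beyond the scatter). This position can therefore bring the number down from the limit of the assay, which the exchange of trifluoromethyl for trifluoromethoxy could not show. The full size of both steps stays unknown, as each starts from a compound that sits at a limit: the limit of > 40000 nM in this assay, at which 2 of the 3 values shown sit.

The change alters both the substituent and its place on the phenyl ring, and the compounds shown do not separate these two parts. They also leave open how a plain phenyl, or a phenyl carrying an amine or a carboxylic acid, would read on this aromatic nitrogen in this assay.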